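Swapping the benzyl for a butynyl chain on the sulfonamide nitrogen

A few compounds are considered here, and "the series" means these few. Any claim that something is new, unique, unknown or untested is made for them only; others in the source may bear on it.

Among the compounds with values here, compound 1 `O=C1c2ccccc2N(Cc2ccccc2)S(=O)(=O)N1Cc1ccccc1` is measured in a functional assay on MRC5 cells (Homo sapiens) (a lower number here means that less compound is tolerated, a higher number that more compound is tolerated), at 66000 nM, the higher of the two numbers known so far. Compound 2 `O=C1c2ccccc2N(Cc2ccccc2)S(=O)(=O)N1Cc1ccccc1Cl` gives 60000 nM in this assay. The step of a 1.1-fold lower number from compound 1 to compound 2 (0.04 log units; within the scatter) lies within the scatter. Compound 3 `C#CCCN1c2ccccc2C(=O)N(Cc2ccccc2)S1(=O)=O` differs from compound 1 by propargyl in place of phenyl on a saturated chain carbon bound to a sulfonamide nitrogen in a ring. Within the data shown here, no measured step touches this position, and the single step known, chloro in place of hydrogen on an aromatic carbon, is itself within the scatter, so no change beyond the scatter is expected. Compound 3 is therefore estimated at 66000 nM, with a range from 25000 nM to 150000 nM, meaning a step of no change at the digits printed from compound 1 to compound 3 (within the scatter).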

Compound 3, half-maximal cytotoxic concentration: 77000 nM
The estimate for compound 3 lay 1.2-fold (0.07 log units) below the measured number; the measured number falls inside the stated range.
By their numbers in this assay, from the lowest: compounds 2, 1 and 3 (each within the scatter of the next).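

In this assay, a phenyl gives way to propargyl on a saturated chain carbon bound to a sulfonamide nitrogen in a ring, and the result stays within the scatter (a 1.2-fold higher number from compound 1 to compound 3 (0.07 log units; within the scatter)). This position, which the earlier chloro step did not touch, therefore accepts the loss of this aromatic ring without a change beyond the scatter. No measurement available here offers an explanation for this. Still open, on these data alone, is whether an amine, a carboxylic acid or a longer chain at this place would also leave the number within the scatter.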